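Replacing the 2-carboxyethyl group of compound 1 with tert-butoxy

A few compounds are considered here, and "the series" means these few. Any claim that something is new, unique, unknown or untested is made for them only; others in the source may bear on it.

Measured in a functional assay on MCF7 cells (Homo sapiens) for antiproliferative activity, read by luminescence, with a stated time of 24 h; a lower number here means a stronger inhibitor, a higher number a weaker inhibitor:
Compound 1 `Cc1c(C)c2c(c(C)c1OC(=O)CCC(=O)O)CCC(C)(COc1ccc(CC3SC(=O)NC3=O)cc1)O2`: > 50000 nM
Compound 2 `Cc1c(C)c2c(c(C)c1OC(=O)CCCC[C@@H]1SC[C@@H]3NC(=O)N[C@@H]31)CCC(C)(COc1ccc(CC3SC(=O)NC3=O)cc1)O2`: 15900 nM
Compound 3 `Cc1c(C)c2c(c(C)c1O)CCC(C)(COc1ccc(/C=C3\SC(=O)NC3=O)cc1)O2`: 29700 nM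

Compound 1 sits at the limit of > 50000 nM in this assay, at which 1 of the 3 values shown sits. As far as these compounds go, that figure is a limit and not a number, so the true position of compound 1 is unknown.

The next compound to be tested is compound 4 `Cc1c(C)c2c(c(C)c1OC(=O)OC(C)(C)C)CCC(C)(COc1ccc(CC3SC(=O)NC3=O)cc1)O2`. It carries tert-butoxy in place of 2-carboxyethyl on a carbonyl carbon. The shared core is untouched.

Among the measured compounds shown here, only one measured step bears on this change, because it also removes the carboxyl end of that same group: an at least 3.1-fold lower number from compound 1 to compound 2 (0.49 log units; beyond the scatter). The group that enters there is very different from tert-butoxy, so this is a weak guide. It still points to a modest move toward a lower number in this assay, not a large one.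

The expected step is an at least 2.0-fold lower number from compound 1 to compound 4 (0.30 log units; that floor lies within the scatter).

For compound 4 the estimated value is 25000 nM, with an expected range from 10000 nM to 60000 nM.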

Compound 4, half-maximal inhibitory concentration: 11200 nM
Estimate against measurement, compound 4: 2.2-fold (0.35 log units) above; measured number inside the range.
By their numbers in this assay, from the lowest: compounds 4, 2 and 3 (each within the scatter of the next, the first and the last beyond it). At a limit, above all of these: compound 1.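

In this assay, tert-butoxy in place of 2-carboxyethyl gives an at least 4.4-fold lower number from compound 1 to compound 4 (0.64 log units; beyond the scatter), so a large entering group with two rings is not needed for a drop at this place: tert-butoxy has no ring and the same count of heavy atoms as the group it replaces. Compound 4 at 11200 nM and compound 2 at 15900 nM lie within the scatter of each other, even though the two entering groups are very different. The true size of the step stays unknown, as the figure for compound 1 is a limit: the limit of > 50000 nM in this assay, at which 1 of the 4 values shown sits.

The compounds shown leave open whether the drop follows from losing the carboxylic acid or from gaining the tert-butyl carbons, a question that a methyl ester of the same chain would help to separate. As far as these compounds go, how an amine at the end of that chain would read in this assay also remains open.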